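Amide substitution on the aryloxyacetamide series

A few compounds are considered here, and "the series" means these few. Any claim that something is new, unique, unknown or untested is made for them only; others in the source may bear on it.

Compound 1 `CCCCc1oc2ccccc2c1C(=O)c1ccc(OCC(N)=O)cc1`: in a functional assay on MCF7 cells (Homo sapiens) for antiproliferative activity, read by MTT assay, with a stated time of 24 h (a higher number here means a weaker inhibitor, a lower number a stronger inhibitor), compound 1 gives > 50000 nM, a limit of the assay.
Compound 2 `CCCCNC(=O)COc1ccc(C(=O)c2c(CCCC)oc3ccccc23)cc1`: in this assay compound 2 gives > 50000 nM, a limit.
Compound 3 `CCCCc1oc2ccccc2c1C(=O)c1ccc(OCC(=O)N2CCCCC2)cc1`: in this assay compound 3 gives > 50000 nM, a limit.

Compound 1 stands only at a limit in this assay, not at a number. The same holds for every other compound measured: the limit of > 50000 nM in this assay, at which 3 of the 3 values shown sit. Compound 4 `CCCCc1oc2ccccc2c1C(=O)c1ccc(OCC(=O)Nc2ccccc2)cc1` differs from compound 1 in one place, (phenyl in place of hydrogen on an amide-type nitrogen).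

The measured steps that touch the same amide-type nitrogen are a step that the two limits leave unreadable from compound 1 to compound 2 and a step that the two limits leave unreadable from compound 2 to compound 3, together with a step that the two limits leave unreadable from compound 1 to compound 3 on the carbonyl carbon. None of them has a readable size, since each pair sits at the limit on both sides. For the measured compounds named here, they therefore give no direction for the step to compound 4; what they do show is that changes of this kind at the amide position have not moved any compound to a numbered value.

Compound 4 is therefore expected to remain at or near the limit, with an estimated value of 60000 nM, in the range 20000 nM to 200000 nM. The step this estimate implies, a step that the limit leaves unreadable from compound 1 to compound 4, is expected to be unreadable, with a limit the most likely outcome.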

Compound 4, half-maximal inhibitory concentration: 33600 nM
The estimate for compound 4 lay 1.8-fold (0.25 log units) above the measured number; low and high end bracket the measured number.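

Phenyl on the amide-type nitrogen is the only change at this position among those shown that yields a number rather than a limit in this assay, giving an at least 1.4-fold lower number from compound 1 to compound 4 (0.17 log units; that floor lies within the scatter). The comparisons with the two other substituted amides read the same way, with an at least 1.4-fold lower number from compound 2 to compound 4 (0.17 log units; that floor lies within the scatter) and an at least 1.4-fold lower number from compound 3 to compound 4 (0.17 log units; that floor lies within the scatter), so anilino on the carbonyl carbon separates from butylamino and piperidin-1-yl only in leaving the limit. Each of these three floors lies within the scatter, and the true size of each step stays unknown because the other side of every comparison is only a limit: the limit of > 50000 nM in this assay, at which 3 of the 4 values shown sit.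

The steps among compound 1, compound 2 and compound 3 cannot be read, so any differences among those three amides remain hidden, and a real gain for compound 4 is not established. The compounds shown leave open whether the aromatic ring must sit directly on the amide-type nitrogen, as a benzyl group on that nitrogen would test, and whether the amide itself is needed, as a carboxylic acid in its place would test.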